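The source may report more compounds than this note shows. Statements on the series, on what has been measured and on what is new or still open speak of the compounds shown alone.

Measured in a toxicity assay on THP-1 cells (Homo sapiens) for inhibition; a lower number here means that less compound is tolerated, a higher number that more compound is tolerated:
- compound 1 `Cn1c(-c2ccccc2)cnc1NC(=O)c1ccc(F)cc1`: > 100000 nM
- compound 2 `Cc1ccc(-c2cnc(NC(=O)c3ccc(F)cc3)n2C)cc1`: 60000 nM
- compound 3 `Cn1c(-c2cccc(Cl)c2)cnc1NC(=O)c1ncc[nH]1`: 55000 nM

Compound 1 has the entry > 100000 nM, which is a limit of the assay and not a number. Compound 3, at 55000 nM, lies within the scatter of compound 2, at 60000 nM. Compound 4 `Cn1c(-c2cccc(Cl)c2)cnc1NC(=O)c1ccc(F)cc1` is compound 3 with one change: 4-fluorophenyl in place of 1H-imidazol-2-yl on a carbonyl carbon. Within the data shown here, the only measured step, an at least 1.6-fold lower number from compound 1 to compound 2 (0.22 log units; that floor lies within the scatter), starts from the limit of > 100000 nM in this assay, at which 1 of the 3 values shown sits, and involves methyl in place of hydrogen on an aromatic carbon, so it does not test this change. Compound 2 already carries 4-fluorophenyl on the carbonyl carbon and gives 60000 nM, so no step beyond the scatter is expected. The expected change is a 1.2-fold higher number from compound 3 to compound 4 (0.07 log units; within the scatter). For compound 4 the estimated value is 65000 nM, with an expected range of 30000 nM to 100000 nM.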

Compound 4, half-maximal cytotoxic concentration: > 50000 nM
Compound 4: a limit, no number; the forecaster's own chance of this, stated with the estimate: 25%; the middle value is on the limit's open side.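

In this assay compound 4 gives > 50000 nM, which is a limit of the assay and not a number. The steps to it from compound 1, compound 2 and compound 3 cannot be read. The compounds shown leave open whether 4-fluorophenyl in place of 1H-imidazol-2-yl on a carbonyl carbon shifts the tolerated concentration at all.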